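A Single Methoxy Added to Compound 1

The source may hold more compounds than are shown below. What is called first, only, known or untested is meant among the compounds shown, and "the series" means these compounds.

compound 1 `CCOC(=O)CNc1nc(Nc2ccccc2)ncc1[N+](=O)[O-]` — 54300 nM
compound 2 `CCOC(=O)CN(Cc1ccccc1)c1nc(Nc2ccccc2)ncc1[N+](=O)[O-]` — > 100000 nM (a limit, not a number)
compound 3 `CCOC(=O)CN(Cc1ccccc1)c1nc(Nc2cc(OC)c(OC)c(OC)c2)ncc1[N+](=O)[O-]` — 40400 nM

In a functional assay on MDA-MB-231 cells (Homo sapiens) for antiproliferative activity, read by MTT assay, with a stated time of 48 h (a lower number here means a stronger inhibitor, a higher number a weaker inhibitor), compound 1 gives 54300 nM, the higher of the two numbers reported. Compound 3 sits nearest, and its number lies within the scatter of that of compound 1. For compound 2 the result is the limit of > 100000 nM in this assay, at which 1 of the 3 values shown sits, so it is a limit and not a number.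

Two steps connect the measured compounds. Benzyl in place of hydrogen on a nitrogen gives an at least 1.8-fold higher number from compound 1 to compound 2 (0.26 log units; that floor lies within the scatter). 3,4,5-Trimethoxyphenyl in place of phenyl gives an at least 2.4-fold lower number from compound 2 to compound 3 (0.39 log units; beyond the scatter).

Compound 4 `CCOC(=O)CNc1nc(Nc2cccc(OC)c2)ncc1[N+](=O)[O-]` differs from compound 1 by methoxy in place of hydrogen on an aromatic carbon. Only the second measured step bears on it, since it also places methoxy on that phenyl ring, though with three methoxy groups rather than one and on a benzyl-bearing core. From it a lowering of the number in this assay of at most modest size is expected, and one that may stay within the scatter; the step from compound 1 to compound 4 is expected to be a 1.6-fold lower number from compound 1 to compound 4 (0.19 log units; within the scatter).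

Compound 4 is therefore expected to give about 35000 nM, with a range from 12000 nM to 100000 nM.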

Compound 4, half-maximal inhibitory concentration: 31300 nM
For compound 4 the middle estimate is 1.1-fold (0.05 log units) above the measured one, within the range that was stated.
By their numbers in this assay, from the lowest: compounds 4, 3 and 1 (each within the scatter of the next). At a limit, above all of these: compound 2.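

Methoxy in place of hydrogen on an aromatic carbon, meta to a large group, appears here as a single change on the core of compound 1, with no benzyl on the nitrogen. In this assay this gives a 1.7-fold lower number from compound 1 to compound 4 (0.24 log units; within the scatter), so one methoxy at this place on the phenyl ring does not shift the result beyond the usual scatter of the assay, and the core of compound 1 tolerates the group without any clear gain or loss. For the compounds shown here, the earlier compounds could not show this, since their only change on this ring put three methoxy groups on the benzyl-bearing core of compound 2, whose result is a limit and not a number, and nothing measured here accounts for the size of the new step.

As far as these compounds go, whether a hydroxyl, an amine or a carboxylic acid at this same place would move the number beyond the scatter stays open. From the compounds shown here alone, it also stays open how a single methoxy would act on the benzyl-bearing core of compound 2, or whether a longer chain in place of the methoxy would change the picture.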